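A few compounds are considered here, and "the series" means these few. Any claim that something is new, unique, unknown or untested is made for them only; others in the source may bear on it.

Three compounds of the series carry numbers in a functional assay on MCF7 cells (Homo sapiens) for cytotoxicity, read by sulforhodamine B assay, with a stated time of 72 h; a lower number here means a stronger inhibitor, a higher number a weaker inhibitor. Compound 1 `CCS(=O)(=O)Nc1cc(-c2ccc3ncnc(Nc4cccc(F)c4)c3c2)cnc1OC` gives 8020 nM. Compound 2 `CCS(=O)(=O)Nc1cc(-c2ccc3ncnc(Nc4ccc(OC)cc4)c3c2)cnc1OC` gives 1790 nM, and compound 3 `CCS(=O)(=O)Nc1cc(-c2ccc3ncnc(Nc4ccc(OC)c(OC)c4)c3c2)cnc1OC` gives 2430 nM. Compound 2 holds the lowest of the three numbers, with compound 3 nearest and compound 1 furthest. The steps of a 4.5-fold lower number from compound 1 to compound 2 (0.65 log units; beyond the scatter) and a 3.3-fold lower number from compound 1 to compound 3 (0.52 log units; beyond the scatter) are both beyond the scatter, whereas a 1.4-fold higher number from compound 2 to compound 3 (0.13 log units; within the scatter) is within it.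

Compound 4 `CCS(=O)(=O)Nc1cc(-c2ccc3ncnc(Nc4ccc(F)c(C(=O)OC)c4)c3c2)cnc1OC` has not yet been measured. It differs from compound 2 in one place: 4-fluoro-3-(methoxycarbonyl)phenyl in place of 4-methoxyphenyl on a nitrogen on an aromatic ring. The measured steps bearing on this are those that exchange the ring on this nitrogen: leaving the 3-fluorophenyl of compound 1 for a methoxyphenyl lowered the number modestly, and a further methoxy in compound 3 did nothing beyond the scatter. The new group in compound 4 again carries a fluorine, here together with a methoxycarbonyl, and the methoxy is gone. A modest step upward in this assay is therefore expected, roughly reversing the earlier gain. For compound 4 the expected number is 5000 nM, with a range from 1500 nM to 15000 nM. The step this estimate means for compound 4 is a 2.8-fold higher number from compound 2 to compound 4 (0.45 log units; beyond the scatter).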

Compound 4, half-maximal inhibitory concentration: 1150 nM
Compound 4: the middle estimate sits 4.3-fold (0.64 log units) above what was measured, outside the stated range (below it).
By their numbers in this assay, from the lowest: compounds 4, 2 and 3 (each within the scatter of the next, the first and the last beyond it); then compound 1.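

On the ring carried by this nitrogen, the 4-methoxyphenyl of compound 2 can give way to 4-fluoro-3-(methoxycarbonyl)phenyl, a group with more heavy atoms, with a 1.6-fold lower number from compound 2 to compound 4 (0.19 log units; within the scatter) in this assay. Against the other two rings, the same group gives a 2.1-fold lower number from compound 3 to compound 4 (0.32 log units; beyond the scatter) and a 7.0-fold lower number from compound 1 to compound 4 (0.84 log units; beyond the scatter), so a fluorine on this ring does not by itself go with the high number of compound 1. Nothing available accounts for these numbers.

The compounds shown do not separate the share of the fluorine from that of the methoxycarbonyl. From the compounds shown here alone, how a carboxylic acid or a primary amide in place of the methoxycarbonyl would read remains open, as does any change elsewhere on the shared core.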